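The compounds below may be only part of what the source reports. "The series", "measured", "known", "first", "only" and "open" are said of these compounds alone.

Compound 3 `CCCOc1ccc(C(=O)Nc2cccc(Br)n2)cc1` sits at the high end of the three numbers shown in an in vitro assay on HEK-tsA201 cells for antagonist activity at Neuronal acetylcholine receptor; alpha4/beta2 (Homo sapiens), read by fluorescence and calcium flux (on this read-out higher numbers stand for weaker inhibition and lower numbers for stronger inhibition), with a value of 80700 nM. Compound 2 `C=CCOc1ccc(C(=O)Nc2cccc(Br)n2)cc1` gives 70100 nM, and the step of a 1.2-fold higher number from compound 2 to compound 3 (0.06 log units; within the scatter) stays within the scatter, while compound 1 `C=CCOc1ccc(C(=O)Nc2cccc(C)n2)cc1` gives 6000 nM, a number well apart from that of compound 3. Compound 4 `CCCNc1cccc(NC(=O)c2ccc(OCCC)cc2)n1` differs from compound 3 by propylamino in place of bromo on an aromatic carbon. Within the data shown here, no measured step brings in a propylamino group, but the same ring position has been changed once: a 12-fold higher number from compound 1 to compound 2 (1.07 log units; beyond the scatter) shows that a swap there can move the number by a large amount. A moderate step is therefore expected for compound 4 in this assay, with the direction uncertain, a 2.7-fold lower number from compound 3 to compound 4 (0.43 log units; beyond the scatter). Compound 4 is estimated at 30000 nM, within a range from 5000 nM to 150000 nM.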

Compound 4, half-maximal inhibitory concentration: 15400 nM
Compound 4: middle estimate off by 1.9-fold (0.29 log units), on the high side; measured number inside the range.
By their numbers in this assay, from the lowest: compound 1; then compound 4; then compounds 2 and 3 (each within the scatter of the next).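

With a 5.2-fold lower number from compound 3 to compound 4 (0.72 log units; beyond the scatter) in this assay, this ring carbon proves able to carry propylamino, a larger group than bromo, and the number falls. The earlier change here, a 12-fold higher number from compound 1 to compound 2 (1.07 log units; beyond the scatter), showed only that bromo gives a higher number than methyl. Nothing available explains either shift.

On these data alone, it remains open whether the nitrogen of propylamino or its propyl chain accounts for the lower number. A plain amine and a butyl group on the same carbon would help separate the two.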